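Chloro for methyl on the aryl ether ring

The source may hold more compounds than are shown below. What is called first, only, known or untested is meant among the compounds shown, and "the series" means these compounds.

Measured compounds:
compound 1 `CC[N+]1(CCCCCCCOc2ccc(-n3cc(C(=O)Nc4cc(F)cc(F)c4)c(=O)c4ccc(N(C)C)nc43)cc2C)CCCCC1` — 53.4%
compound 2 `CC[N+]1(CCCCCCCOc2ccc(-n3cc(C(=O)Nc4cc(F)cc(F)c4)c(=O)c4ccc(N(C)C)nc43)cc2Cl)CCCCC1` — 50.4%
compound 3 `Cc1ccc(-n2cc(C(=O)Nc3cc(F)cc(F)c3)c(=O)c3ccc(N(C)C)nc32)cc1OCCCCCCC[N+]1(C)CCN(C)CC1` — 25%

Of the compounds shown here, three have been read in an assay on LX2 cells for inhibition of COL1A1 promoter (Homo sapiens), read by a luciferase reporter, with a stated time of 24 h, tested at 50 uM; on this read-out lower numbers stand for a weaker effect and higher numbers for a stronger effect at the one concentration tested. Compound 1 and compound 2 share one core and differ by a single change, (chloro in place of methyl on an aromatic carbon); the step of a number 3 percentage points lower from compound 1 to compound 2 (within the scatter) lies within the scatter, so the two values are not told apart. Compound 3 has a different core, with a different charged amine at the end of the chain and a different arrangement on the aryl ether ring; the difference between the two cores is not broken down here. In this assay compound 3 gives 25%, the lowest of the three numbers, beyond the scatter from both compound 1 and compound 2.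

Compound 4 `CN1CC[N+](C)(CCCCCCCOc2cc(-n3cc(C(=O)Nc4cc(F)cc(F)c4)c(=O)c4ccc(N(C)C)nc43)ccc2Cl)CC1` has not been measured. It stands to compound 3 as compound 2 stands to compound 1: chloro in place of methyl on an aromatic carbon. The places are not identical: in compound 1 the carbon is ortho to a large group and meta to a large group, in compound 3 it is ortho to a large group and para to a large group, so this is the same kind of change, not the same change. Among the measured compounds shown here, with only one earlier example, which gave a step within the scatter, the step from compound 3 to compound 4 is expected to be small as well, a number 2 percentage points lower from compound 3 to compound 4 (within the scatter), resting on a number 3 percentage points lower from compound 1 to compound 2 (within the scatter). Compound 4 is therefore estimated at 23% in this assay, with a range from 8% to 40% to allow for the different core of compound 3.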

Compound 4, a percentage reported as inhibition, at one concentration (the size of the read-out at that concentration, not a potency): 45.2%
For compound 4 the middle estimate is 22.2 percentage points below the measured one; the measured number lies above the stated range.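

In this assay, chloro in place of methyl on an aromatic carbon gives a number 20.2 percentage points higher from compound 3 to compound 4 (beyond the scatter), while the same kind of change on the core of compound 1 gives a number 3 percentage points lower from compound 1 to compound 2 (within the scatter). In this series the change therefore does not carry over from one core to the other as a step of fixed size: the same change on two cores in this assay, a number 3 percentage points lower (within the scatter) from compound 1 to compound 2 and a number 20.2 percentage points higher (beyond the scatter) from compound 3 to compound 4, 23.2 percentage points apart, beyond the scatter of two such steps This rests on only two pairs, and the two cores differ both in the charged amine at the end of the chain and in the arrangement on the aryl ether ring, so the gap between the steps cannot be assigned to either difference, and no cause for it is shown.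

Open, on these data alone, is how the same change behaves when the charged amine of compound 1 is paired with the ring arrangement of compound 3, and the reverse, since such compounds would separate the two differences between the cores. Also open, as far as these compounds go, is whether other groups on that aromatic carbon, such as fluoro or methoxy, or a longer chain, would follow the step seen on one core or the other.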